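Replacing hydroxy with methylamino on a weak series

A few compounds are considered here, and "the series" means these few. Any claim that something is new, unique, unknown or untested is made for them only; others in the source may bear on it.

Compound 1 (`OC[C@H]1O[C@H](n2cnc3c(O)ncnc32)CS1`) reads > 100000 nM in a functional assay on Vero cells (Chlorocebus sabaeus) for inhibition (on this read-out lower numbers stand for stronger inhibition and higher numbers for weaker inhibition), which is a limit of the assay and not a number. This places it at the edge of the measured range: the limit of > 100000 nM in this assay, at which 1 of the 2 values shown sits. Compound 2 (`Nc1nc(O)c2ncn([C@@H]3CS[C@@H](CO)O3)c2n1`) gives 63600 nM in this assay. Among the measured compounds shown here, the only measured step is an at least 1.5-fold lower number from compound 1 to compound 2 (0.19 log units; that floor lies within the scatter), for amino in place of hydrogen on an aromatic carbon, and it is a different change from the one considered here. Compound 3 (`CNc1ncnc2c1ncn2[C@@H]1CS[C@@H](CO)O1`) carries methylamino in place of hydroxy on an aromatic carbon. For the measured compounds named here, with only that step as a guide, a modest move towards lower numbers in this assay is expected, and a result at the limit would be no surprise. The estimated step is an at least 2.0-fold lower number from compound 1 to compound 3 (0.30 log units; that floor lies within the scatter). For compound 3 the expected value is 50000 nM, with an estimated range of 12000 nM to 150000 nM.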

Compound 3, half-maximal inhibitory concentration: > 100000 nM
Compound 3 ended at the assay's limit; the forecaster's own chance of this, stated with the estimate: 45%; middle value at least 2.0-fold (0.30 log units) from the limit.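

Compound 1 and compound 3 both end at a limit of the assay and not at a number, so no step between them can be read: the limit of > 100000 nM in this assay, at which 2 of the 3 values shown sit.

Left open is whether methylamino in place of hydroxy on an aromatic carbon shifts inhibition in either direction on the shared core.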